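Swapping carboxy for sulfomethyl: an expected cytotoxicity value

This account rests on a few compounds, and the source may have more. Where it says the series, first, only, none or still open, it means among the compounds named here.

Measured so far in a functional assay on Bel-7402 cells (Homo sapiens) for cytotoxicity, read by resazurin assay, with a stated time of 72 h; on this read-out higher numbers stand for weaker inhibition and lower numbers for stronger inhibition:
compound 1 `CC(=O)CCSC(=S)NCc1cccnc1` gives 3430 nM
compound 2 `O=C(O)CCSC(=S)NCc1cccnc1` gives 7420 nM

Among the compounds with values here, compound 2 holds the higher of these two numbers, and the one recorded step, a 2.2-fold higher number from compound 1 to compound 2 (0.34 log units; beyond the scatter), came from hydroxy in place of methyl on a carbonyl carbon. Compound 3 `O=S(=O)(O)CCCSC(=S)NCc1cccnc1` has not yet been measured in this assay. It differs from compound 2 by sulfomethyl in place of carboxy on a saturated chain carbon, two bonds along the chain from a sulfur. Within the data shown here, only the step from compound 1 to compound 2 bears on this change, since it altered the same chain end, and it was modest, just beyond the scatter. A similar modest rise, or no step beyond the scatter, is therefore expected. Compound 3 is expected to give about 9500 nM in this assay, with a range from 3500 nM to 26000 nM. This estimate corresponds to an expected step of a 1.3-fold higher number from compound 2 to compound 3 (0.11 log units; within the scatter).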

Compound 3, half-maximal inhibitory concentration: 6590 nM
Compound 3: the middle estimate sits 1.4-fold (0.16 log units) above what was measured; the measured number falls inside the stated range.
By their numbers in this assay, from the lowest: compounds 1, 3 and 2 (each within the scatter of the next, the first and the last beyond it).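

In this assay, sulfomethyl, with 5 heavy atoms, can stand in place of carboxy, with 3 heavy atoms, at this chain end: the step is a 1.1-fold lower number from compound 2 to compound 3 (0.05 log units; within the scatter) and so does not separate the two compounds. Set against the acetyl end, the same group gives a 1.9-fold higher number from compound 1 to compound 3 (0.28 log units; within the scatter) and so does not separate those two compounds either, even though compound 1 and compound 2 do lie beyond the scatter of each other. Nothing measured here accounts for how little this change alters the number.

The compounds shown leave open whether an amine or a primary amide on this saturated chain carbon, or a longer chain ending in sulfomethyl, would keep the number in this same range. They also leave open whether compound 2 and compound 3 stay this close in other cell lines.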